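The source may hold more compounds than are shown below. What is called first, only, known or untested is meant among the compounds shown, and "the series" means these compounds.

Measured compounds in a functional assay on HEK293 cells (Homo sapiens) for cytotoxicity; a higher number here means that more compound is tolerated, a lower number that less compound is tolerated:

Compound 1 `COc1ccc([C@H]2CC(=O)N(c3ccccc3N)C2)cc1OC1CCCC1` gives > 10000 nM, a limit of the assay.
Compound 2 `COc1ccc([C@H]2CC(=O)N(c3ccc(C)cc3)C2)cc1OC1CCCC1` gives > 10000 nM, a limit of the assay.
Compound 3 `COc1ccc([C@H]2CC(=O)N(c3cccc(NCCCc4ccccc4)c3)C2)cc1OC1CCCC1` gives > 10000 nM, a limit of the assay.

Where compound 3 stands: its value in this assay is only a limit, and the two other values shown are limits as well, so no compound of the series is placed on a number in this assay. For the measured compounds named here, the one measured step, a step that the two limits leave unreadable from compound 1 to compound 2, is left unreadable by the two limits on either side, so its size is unknown.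

The change to compound 4 `COc1ccc([C@H]2CC(=O)N(c3cccc(NS(=O)(=O)c4ccccc4C)c3)C2)cc1OC1CCCC1` is (2-methylphenyl)sulfonyl in place of 3-phenylpropyl on a nitrogen on an aromatic ring. Going by the values given here, no measured step concerns this nitrogen on an aromatic ring, so no step bears directly on it; what is known is the limit of > 10000 nM in this assay, at which 3 of the 3 values shown sit, which holds for every measured compound whatever sits on the amide-type nitrogen in the ring. On that basis no step beyond the scatter is expected in this assay, in either direction, and the most probable outcome for compound 4 is again a limit rather than a number.

Estimate: compound 4 is expected to give 10000 nM in this assay, within 5000 nM to 20000 nM. The expected step of a number no higher from compound 3 to compound 4 (the limit leaves the size open) is thus essentially none.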

Compound 4, half-maximal cytotoxic concentration: > 10000 nM
Compound 4 was reported as a limit; the forecaster's own chance of this, stated with the estimate: 85%; the middle value sits exactly at the limit.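

In this assay compound 3 and compound 4 are both reported only as limits, so no step can be read between them. The compounds shown leave open how far the tolerated concentration of each lies past that limit, and whether they differ from one another at all: the limit of > 10000 nM in this assay, at which 4 of the 4 values shown sit.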